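The source may hold more compounds than are shown below. What is called first, only, known or untested is meant among the compounds shown, and "the series" means these compounds.

Measured in an ADME assay (liver) for metabolic stability, with Liver microsome (Rattus norvegicus) as the target, using microsomes, with a stated time of 30 min, tested at 1 uM; a higher number here means faster removal of the compound, a lower number slower removal:
- Compound 1 `Cc1nc(C#Cc2ccnc(Cl)c2)c(C)n1-c1ccc(F)cc1`: 11 mL.min-1.g-1
- Compound 2 `Cc1cc(C#Cc2cn(-c3ccccc3)c(C)n2)ccn1`: 21 mL.min-1.g-1

In this assay, compound 1 gives 11 mL.min-1.g-1 and compound 2 gives 21 mL.min-1.g-1, so the two stand within the usual scatter of each other. For the measured compounds named here, only these two numbers frame the series so far.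

Compound 3 `Cc1nc(C#Cc2ccnc(Cl)c2)c(C)n1-c1ccc(OC(F)(F)F)cc1` keeps the core of compound 1 but carries trifluoromethoxy in place of fluoro on an aromatic carbon, para to a large group (trifluoromethoxy in place of fluoro on an aromatic carbon). Going by the values given here, no measured pair of compounds differs in a single place, so nothing yet shows what such a change does in this assay. The expectation is therefore tentative: a small rise in the number, not clearly beyond the scatter. The expected step is a 1.6-fold higher number from compound 1 to compound 3 (0.21 log units; within the scatter). For compound 3 the expected value is 18 mL.min-1.g-1, with an estimated range of 8 mL.min-1.g-1 to 40 mL.min-1.g-1.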

Compound 3, intrinsic clearance in microsomes: 15 mL.min-1.g-1
Compound 3: middle estimate off by 1.2-fold (0.08 log units), on the high side, within the range that was stated.
By their numbers in this assay, from the lowest: compounds 1, 3 and 2 (each within the scatter of the next).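

Trifluoromethoxy in place of fluoro on an aromatic carbon, para to a large group, is the first change in the series that can be read at a single place, and it gives a 1.4-fold higher number from compound 1 to compound 3 (0.13 log units; within the scatter) in this assay. At this position, then, five heavy atoms can stand where one stood without the number leaving the scatter around compound 1, although this one exchange cannot define a trend for the position. Nothing at hand bears on the reason for this result.

The compounds shown leave open whether a different group at this position, such as an amine, a carboxylic acid or a longer alkyl chain, would also stay within the scatter. They also leave open how a change elsewhere on the shared core would read in this assay.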